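Benzyloxy in Place of Nitro on Two Related Cores

A few compounds are considered here, and "the series" means these few. Any claim that something is new, unique, unknown or untested is made for them only; others in the source may bear on it.

Compound 1 `COc1ccc(-c2sc(C(=O)O)cc2-c2cc(OC)c(OC)c(OC)c2)cc1[N+](=O)[O-]` carries a nitro group, and in a functional assay on HT-1080 cells (Homo sapiens) for antiproliferative activity, read by MTT assay, with a stated time of 72 h (a lower number here means a stronger inhibitor, a higher number a weaker inhibitor), compound 1 gives 37200 nM. Compound 2 `COc1ccc(-c2sc(C(=O)O)cc2-c2cc(OC)c(OC)c(OC)c2)cc1OCc1ccccc1` differs from it by benzyloxy in place of nitro on an aromatic carbon. In this assay compound 2 reaches only > 100000 nM, which is a limit of the assay rather than a number. As far as these compounds go, the change therefore produces an at least 2.6-fold higher number from compound 1 to compound 2 (0.42 log units; beyond the scatter), and its full size stays open because the limit of > 100000 nM in this assay, at which 1 of the 3 values shown sits, is where compound 2 sits. Compound 3 `COc1ccc(-c2ccsc2-c2cc(OC)c(OC)c(OC)c2)cc1[N+](=O)[O-]` rests on a different core; the difference between the two cores is not broken down here. In this assay compound 3 gives 8040 nM, the lowest of the two numbers. Compound 4 `COc1ccc(-c2ccsc2-c2cc(OC)c(OC)c(OC)c2)cc1OCc1ccccc1` differs from compound 3 by benzyloxy in place of nitro on an aromatic carbon, the same change as that made on compound 1. Since the same change gave an at least 2.6-fold higher number from compound 1 to compound 2 (0.42 log units; beyond the scatter), a comparable weakening is expected here, a 3.7-fold higher number from compound 3 to compound 4 (0.57 log units; beyond the scatter). Compound 4 is accordingly estimated at 30000 nM, between 12000 nM and 100000 nM.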

Compound 4, half-maximal inhibitory concentration: > 100000 nM
Compound 4: no number, only a limit (the forecaster's own chance of this, stated with the estimate: 30%); middle value at least 3.3-fold (0.52 log units) away from the limit.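

In this assay compound 4 gives > 100000 nM, which is a limit of the assay and not a number. Benzyloxy in place of nitro on an aromatic carbon produces an at least 12-fold higher number from compound 3 to compound 4 (1.09 log units; beyond the scatter), so on both cores shown the change raises the number beyond the scatter. This shows that the direction carries over between these two cores, but it does not show that the size does: the same change on two cores in this assay, an at least 2.6-fold higher number (0.42 log units; beyond the scatter) from compound 1 to compound 2 and an at least 12-fold higher number (1.09 log units; beyond the scatter) from compound 3 to compound 4; the limit leaves it open whether they differ

The compounds shown leave open how an amine or a hydroxyl group in that position would compare with nitro on either core. They also leave open whether an ethoxy group, a far shorter ether than benzyloxy, would bring the same rise.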